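A few compounds are considered here, and "the series" means these few. Any claim that something is new, unique, unknown or untested is made for them only; others in the source may bear on it.

Compound 1 `Fc1cccc(Nc2nc(-c3cccc(F)c3)nc3ccc(F)cc23)c1` gives 42300 nM in a functional assay on U-937 cells (Homo sapiens) for cytotoxicity, read by MTT assay, with a stated time of 48 h; on this read-out lower numbers stand for stronger inhibition and higher numbers for weaker inhibition.
Compound 2 `Fc1cccc(-c2nc(Nc3cccc(Cl)c3)c3cc(F)ccc3n2)c1` gives only a limit, > 50000 nM.
Compound 3 `Nc1cccc(Nc2nc(-c3cccc(F)c3)nc3ccc(F)cc23)c1` gives only a limit, > 50000 nM.

Compound 2 therefore stands at the limit of > 50000 nM in this assay, at which 2 of the 3 values shown sit, with no number behind it. Compound 4 `Cc1cccc(Nc2nc(-c3cccc(F)c3)nc3ccc(F)cc23)c1` differs from it in one place: methyl in place of chloro on an aromatic carbon. The measured steps that come closest are an at least 1.1-fold higher number from compound 1 to compound 2 (0.07 log units; that floor lies within the scatter) and an at least 1.1-fold higher number from compound 1 to compound 3 (0.07 log units; that floor lies within the scatter), both too small to read, and a step that the two limits leave unreadable from compound 2 to compound 3. None of them involves a methyl, and all three compounds sit in the weak range, so no shift beyond the scatter is expected. Compound 4 is therefore expected near 50000 nM, between 20000 nM and 150000 nM. That estimate means a step of a number no higher from compound 2 to compound 4 (the limit leaves the size open).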

Compound 4, half-maximal inhibitory concentration: > 50000 nM
Compound 4 was reported as a limit; the forecaster's own chance of this, stated with the estimate: 60%; the middle value sits exactly at the limit.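

For the compounds shown here, compound 4, with its 3-methylphenyl group, gives only a limit in this assay, so methyl joins chloro and amino as changes at this place that leave no number to compare: the limit of > 50000 nM in this assay, at which 3 of the 4 values shown sit. The one step with a floor, an at least 1.1-fold higher number from compound 1 to compound 4 (0.07 log units; that floor lies within the scatter), is too small to read, and the steps linking compound 2, compound 3 and compound 4 cannot be read at all. Fluoro in compound 1 therefore remains the only group here with a measured number.

On these data alone, how far the true values of compound 2, compound 3 and compound 4 lie beyond the limit stays open. So does whether a carboxylic acid, a methoxy group or a longer chain at this place would give a clearly lower number.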